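Working notes: from compound 2 to compound 3

This account rests on a few compounds, and the source may have more. Where it says the series, first, only, none or still open, it means among the compounds named here.

In a functional assay on MCF7 cells (Homo sapiens) for cytotoxicity, read by sulforhodamine B assay, with a stated time of 24 h (a lower number here means a stronger inhibitor, a higher number a weaker inhibitor), compound 2 `O=C1Nc2ccc(S(=O)(=O)N3CCOCC3)cc2/C1=N/Nc1ccccc1` gives 30300 nM. For the measured compounds named here, its only measured neighbour, compound 1 `O=C1Nc2ccc(S(=O)(=O)N3CCOCC3)cc2/C1=N/c1cccc(C(F)(F)F)c1`, gives 41100 nM. The two numbers lie within the scatter of each other, so neither stands apart.

The next structure, compound 3 `CC(=O)c1cccc(/N=C2\C(=O)Nc3ccc(S(=O)(=O)N4CCOCC4)cc32)c1`, keeps the shared core and differs from compound 2 as follows: 3-acetylphenyl in place of anilino on a double-bonded nitrogen. In words, this is 3-acetylphenyl in place of anilino on a double-bonded nitrogen.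

Going by the values given here, one measured step bears on this change: a 1.4-fold lower number from compound 1 to compound 2 (0.13 log units; within the scatter). It involves the same anilino group at the same place, set against 3-(trifluoromethyl)phenyl, and it stays within the scatter. Compound 3, like compound 1, carries a phenyl group there in place of anilino. Among the compounds with values here, no compound with an acetyl group has been measured yet, so this single step is thin support. On that evidence, no step beyond the scatter is expected. The expected step is a 1.2-fold higher number from compound 2 to compound 3 (0.06 log units; within the scatter). For compound 3 the estimated value is 35000 nM, with an expected range from 15000 nM to 80000 nM.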

Compound 3, half-maximal inhibitory concentration: 39200 nM
The estimate for compound 3 lay 1.1-fold (0.05 log units) below the measured number; the range from low to high includes it.
By their numbers in this assay, from the lowest: compounds 2, 3 and 1 (each within the scatter of the next).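

In this assay the change from anilino to 3-acetylphenyl on a double-bonded nitrogen gives a 1.3-fold higher number from compound 2 to compound 3 (0.11 log units; within the scatter) and stays within the scatter, so a second aryl group at this place, now carrying acetyl, also leaves the number where compound 1 and compound 2 stand. The swap of acetyl in place of trifluoromethyl on an aromatic carbon, which the earlier pair could not address, gives a 1.0-fold lower number from compound 1 to compound 3 (0.02 log units; within the scatter) and also stays within the scatter, so these two groups cannot be told apart in this assay and all three compounds form one group with no step beyond the scatter. Nothing available explains this flat reading.

The compounds shown leave open whether any group at this place can move the number beyond the scatter, since an amine or a carboxylic acid on the aromatic ring, or a longer chain in place of acetyl, has no value here. On these data alone, the shared core is the same in all three compounds, so what a change there would do also stays open.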